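A few compounds are considered here, and "the series" means these few. Any claim that something is new, unique, unknown or untested is made for them only; others in the source may bear on it.

Measured in a functional assay (aorta) with Rattus norvegicus as the target; a lower number here means that less compound is needed, a higher number that more compound is needed for the effect:
- compound 1 `CC(C)NC1=NS(=O)(=O)c2cc(F)ccc2N1`: 43.1 uM
- compound 2 `CCC(C)NC1=NS(=O)(=O)c2cc(F)ccc2N1`: 39.2 uM
- compound 3 `O=S1(=O)NC(NC2CC2)=Nc2ccc(F)cc21`: > 300 uM

Compound 3 has no number in this assay, only a limit: the limit of > 300 uM in this assay, at which 1 of the 3 values shown sits. Compound 4 `O=S1(=O)NC(NC2CCC2)=Nc2ccc(F)cc21` differs from compound 3 in one place: cyclobutyl in place of cyclopropyl on an amine nitrogen. It carries cyclobutyl in place of cyclopropyl on an amine nitrogen.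

Going by the values given here, no measured step starts from compound 3, so the ring change has not been measured directly. Among the compounds with values here, the only step available, a 1.1-fold lower number from compound 1 to compound 2 (0.04 log units; within the scatter), is a methyl in place of hydrogen on a saturated chain carbon. Enlarging that open chain therefore gave no change beyond the scatter, but this says little about a ring.

The direction of the expected step rests on compound 1 at 43.1 uM and compound 2 at 39.2 uM, which both give numbers. A number is expected for compound 4 as well, and a lower one than the limit, although a result at the limit remains possible. For compound 4 the estimate is 80 uM, with an expected range from 25 uM to 300 uM. This expectation amounts to an estimated at least 3.7-fold lower number from compound 3 to compound 4 (0.57 log units; beyond the scatter).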

Compound 4, concentration for half-maximal effect: 71.8 uM
Compound 4: middle estimate off by 1.1-fold (0.05 log units), on the high side; measured number inside the range.
By their numbers in this assay, from the lowest: compounds 2, 1 and 4 (each within the scatter of the next). At a limit, above all of these: compound 3.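

In this assay, cyclobutyl in place of cyclopropyl on an amine nitrogen gives an at least 4.1-fold lower number from compound 3 to compound 4 (0.62 log units; beyond the scatter), whereas the earlier open-chain change, a 1.1-fold lower number from compound 1 to compound 2 (0.04 log units; within the scatter), gave no difference that could be told from the scatter. The result therefore shows that the group on this amine nitrogen can matter, and that a change between two small carbon rings is enough to show it. Compound 3 has only a limit, so this step gives a bound and not an exact size: the limit of > 300 uM in this assay, at which 1 of the 4 values shown sits.

Among the compounds shown, cyclopropyl alone stands apart, since compounds 2, 1 and 4 lie each within the scatter of the next, and this holds for the cyclobutyl ring as well as for the two open chains. From the compounds shown here alone, what stays open is how far the trend runs, whether a cyclopentyl or cyclohexyl ring on the same nitrogen would keep a number like that of compound 4 or whether a longer chain would do the same, and whether the ring change would read alike with chlorine in place of the fluorine on the shared core.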